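The source may hold more compounds than are shown below. What is called first, only, known or untested is meant among the compounds shown, and "the series" means these compounds.

Compound 1 `C=CCOc1ccc(C(=O)Nc2ccccn2)cc1`: 19300 nM
Compound 2 `C=CCOc1ccc(C(=O)Nc2cccc(Cl)n2)cc1`: > 100000 nM

Both measured compounds share one core and were tested in an in vitro assay on HEK-tsA201 cells for antagonist activity at Neuronal acetylcholine receptor; alpha4/beta2 (Homo sapiens), read by fluorescence and calcium flux; a lower number here means a stronger inhibitor, a higher number a weaker inhibitor. Compound 1 gives 19300 nM. Compound 2 gives > 100000 nM, a limit of the assay and not a number, so compound 2 stands at the limit of > 100000 nM in this assay, at which 1 of the 2 values shown sits, the weak end of what the assay can show. Among the measured compounds shown here, the single measured step, an at least 5.1-fold higher number from compound 1 to compound 2 (0.71 log units; beyond the scatter), made the inhibitor weaker.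

Compound 3 `C=CCOc1ccc(C(=O)Nc2cccc(NCCC)n2)cc1` is not yet measured. It differs from compound 2 by propylamino in place of chloro on an aromatic carbon. For the measured compounds named here, no measured step shows what a propylamino group does at this place; the one step in hand concerns chloro replacing hydrogen. Compound 3 is therefore expected to stay weak, with the step of an at least 2.0-fold lower number from compound 2 to compound 3 (0.30 log units; that floor lies within the scatter) estimated only roughly, and with a real chance that compound 3 again gives a limit. For compound 3 the estimate is 50000 nM, expected between 8000 nM and 300000 nM.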

Compound 3, half-maximal inhibitory concentration: 14800 nM
Estimate against measurement, compound 3: 3.4-fold (0.53 log units) above; the measured number falls inside the stated range.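

Replacing chloro with propylamino next to the ring nitrogen gives an at least 6.7-fold lower number from compound 2 to compound 3 (0.82 log units; beyond the scatter) in this assay, so a substituent at this place does not have to leave a compound as weak as compound 2. That step starts from a limit of the assay and not from a number: the limit of > 100000 nM in this assay, at which 1 of the 3 values shown sits. Compared with hydrogen at the same place, propylamino gives a 1.3-fold lower number from compound 1 to compound 3 (0.12 log units; within the scatter), so the two groups cannot be told apart in this assay.

The compounds shown leave open how a shorter chain such as methylamino, a longer chain such as butylamino, or a dipropylamino group, which has no hydrogen on its nitrogen, would read at this place. They also cannot separate the part played by the nitrogen of propylamino from that of its carbon chain, a question that a plain propyl group would help to answer.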